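Hydroxymethyl on an Ethylamino Chain, Two Cores Compared

A few compounds are considered here, and "the series" means these few. Any claim that something is new, unique, unknown or untested is made for them only; others in the source may bear on it.

Of the compounds shown here, three with a shared core have been tested in an assay on isolated protein for binding affinity to adenosine receptor A1 (Bos taurus); on this read-out lower numbers stand for stronger inhibition and higher numbers for weaker inhibition. Compound 3 `CCNc1nc(-c2ccccc2)nc2c1nnn2Cc1ccccc1` gives 91000000 nM. Compound 1 `OCCCNc1nc(-c2ccccc2)nc2c1nnn2Cc1ccccc1` carries hydroxymethyl in place of hydrogen on a saturated chain carbon, two bonds along the chain from a nitrogen on an aromatic ring and gives 21400000 nM, a move of a 4.3-fold lower number from compound 3 to compound 1 (0.63 log units; beyond the scatter). Compound 2 `CCNc1nc(-c2ccccc2)nc2c1nnn2Cc1ccccc1F` gives 11000000 nM; from compound 2 to compound 3 the number rises by an 8.3-fold higher number from compound 2 to compound 3 (0.92 log units; beyond the scatter), while compound 2 and compound 1 sit within the scatter of each other.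

Compound 4 `OCCCNc1nc(-c2ccccc2)nc2c1nnn2Cc1ccccc1F` has not yet been measured. Relative to compound 2 it carries hydroxymethyl in place of hydrogen on a saturated chain carbon, two bonds along the chain from a nitrogen on an aromatic ring, the same change as from compound 3 to compound 1; the two cores differ by fluoro in place of hydrogen on an aromatic carbon. Because that change once gave a 4.3-fold lower number from compound 3 to compound 1 (0.63 log units; beyond the scatter), compound 4 is expected to show a 4.2-fold lower number from compound 2 to compound 4 (0.63 log units; beyond the scatter). Compound 4 is therefore estimated at 2600000 nM, with a likely range from 1000000 nM to 7000000 nM.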

Compound 4, inhibition constant: 3700000 nM
Compound 4: the middle estimate sits 1.4-fold (0.15 log units) below what was measured; the measured number falls inside the stated range.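

In this assay, hydroxymethyl in place of hydrogen on the fluoro-bearing core gives a 3.0-fold lower number from compound 2 to compound 4 (0.47 log units; beyond the scatter), and this step matches the one on the core without fluoro: the same change on two cores in this assay, a 4.3-fold lower number (0.63 log units; beyond the scatter) from compound 3 to compound 1 and a 3.0-fold lower number (0.47 log units; beyond the scatter) from compound 2 to compound 4, 1.4-fold (0.16 log units) apart, within the scatter of two such steps. Fluoro in place of hydrogen likewise gives a 5.8-fold lower number from compound 1 to compound 4 (0.76 log units; beyond the scatter), which matches its step on the ethylamino compounds: the same change on two cores in this assay, an 8.3-fold higher number (0.92 log units; beyond the scatter) from compound 2 to compound 3 and a 5.8-fold higher number (0.76 log units; beyond the scatter) from compound 4 to compound 1, 1.4-fold (0.16 log units) apart, within the scatter of two such steps. Across these four compounds the two changes therefore behave as independent of each other, but this does not show that they would do so on any other core, nor does it explain why either change lowers the number.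

The compounds shown leave open whether a longer chain, an amine or a carboxylic acid in place of hydroxymethyl would follow the same step. They also leave open whether chloro in place of fluoro would carry over in the same way.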